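The source may report more compounds than this note shows. Statements on the series, on what has been measured and on what is new or still open speak of the compounds shown alone.

Measured in a functional assay on MOLT-4 cells (Homo sapiens) for inhibition; on this read-out lower numbers stand for stronger inhibition and higher numbers for weaker inhibition:
- Compound 1 `O=C1/C(=C/c2cccc(Br)c2)Cc2ccccc21`: 173000 nM
- Compound 2 `O=C1/C(=C/c2ccc(Br)cc2)Cc2ccccc21`: > 500000 nM
- Compound 3 `O=C1/C(=C/c2ccc(Cl)cc2)CCCc2ccccc21`: 33000 nM

Compound 2 gives > 500000 nM, and this is a limit of the assay rather than a number. That leaves two true numbers to compare in this assay. Compound 1 gives 173000 nM, while compound 3 gives 33000 nM. Compound 3 therefore holds the lower of the two, and the gap between them lies beyond the scatter of repeated measurements.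

The next compound is compound 4 `CN(C)c1ccc(/C=C2\CCCc3ccccc3C2=O)cc1`. It keeps the core of compound 3 and carries dimethylamino in place of chloro on an aromatic carbon, para to a large group: dimethylamino in place of chloro on an aromatic carbon.

Going by the values given here, no two measured compounds here differ in only one place, so the data give no direct measure of what a swap like this does. With no such guide, the starting point is compound 3 at 33000 nM, and no change beyond the scatter is expected in this assay, in either direction. The expected 1.1-fold lower number from compound 3 to compound 4 (0.04 log units; within the scatter) is accordingly small. The estimate for compound 4 is 30000 nM, with an expected range from 8000 nM to 120000 nM.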

Compound 4, half-maximal inhibitory concentration: 5250 nM
Beside the measured number, compound 4's estimate is 5.7-fold (0.76 log units) above it, outside the stated range (below it).
By their numbers in this assay, from the lowest: compound 4; then compound 3; then compound 1. At a limit, above all of these: compound 2.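

Going by these compounds alone, the swap of chloro for dimethylamino on an aromatic carbon, para to a large group, gives the first direct comparison between two compounds in this assay, a step of a 6.3-fold lower number from compound 3 to compound 4 (0.80 log units; beyond the scatter). It shows that, on the core shared by these two compounds, the number depends on which group sits at this position, and here the change goes towards stronger inhibition. The group that enters has more heavy atoms than chloro and counts one hydrogen-bond acceptor where chloro counts none, but this single pair cannot connect either difference to the lower number, and nothing measured here gives a reason for the step.

Other groups at this position remain open, such as an unsubstituted amine, a methoxy group or a diethylamino group, and so does whether the lower number follows the nitrogen or would appear with other replacements for chloro. Also open, from the compounds shown here alone, is whether dimethylamino would produce a similar step at another place on this ring or on the core of compound 1.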